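Halogen pattern on the benzyl thiourea arm

The compounds below may be only part of what the source reports. "The series", "measured", "known", "first", "only" and "open" are said of these compounds alone.

Three thioureas with a pivalate ester chain have been measured in an assay on CHO cells for displacement of a labelled ligand from transient receptor potential cation channel subfamily V member 1 (Rattus norvegicus); on this read-out lower numbers stand for stronger inhibition and higher numbers for weaker inhibition. Compound 1 `COc1cc(CNC(=S)NCC(COC(=O)C(C)(C)C)Cc2ccc(C(C)(C)C)cc2)c(Br)cc1O` gives 12.8 nM. Compound 2 `COc1cc(CNC(=S)NCC(COC(=O)C(C)(C)C)Cc2ccc(C)c(C)c2)cc(Br)c1O` gives 33.1 nM. Compound 3 `COc1cc(CNC(=S)NC(CCc2ccc(C(C)(C)C)cc2)COC(=O)C(C)(C)C)cc(Cl)c1O` gives 122 nM, the highest of the three numbers; it stands beyond the scatter from both, nearest to compound 2 and furthest from compound 1. No pair among these three differs in a single place, so the numbers only bracket the series and no single step can be read out of them.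

Compound 4 `COc1cc(CNC(=S)NC(CCc2ccc(C(C)(C)C)cc2)COC(=O)C(C)(C)C)c(Br)cc1O` is not yet measured. It differs from compound 3 by 2-bromo-4-hydroxy-5-methoxyphenyl in place of 3-chloro-4-hydroxy-5-methoxyphenyl on a saturated chain carbon bound to an amide-type nitrogen. Within the data shown here, the entering ring is the one carried by compound 1, whose value of 12.8 nM is the lowest seen; the leaving ring is related to the halogen pattern of compound 2, which gives 33.1 nM. Since the other arm of compound 4 remains that of compound 3, the change is expected to move the number downward by a modest step, a 2.4-fold lower number from compound 3 to compound 4 (0.39 log units; beyond the scatter), beyond the scatter but short of the gap between compound 3 and compound 1. Compound 4 is therefore estimated at 50 nM, with a plausible range from 20 nM to 150 nM.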

Compound 4, inhibition constant: 75 nM
For compound 4 the middle estimate is 1.5-fold (0.18 log units) below the measured one, within the range that was stated.
By their numbers in this assay, from the lowest: compound 1; then compound 2; then compounds 4 and 3 (each within the scatter of the next).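

Among these compounds, this is the first pair that differs in one place, so it gives the first direct reading of the halogen-bearing ring on the chain shared by compound 3 and compound 4. In this assay, 2-bromo-4-hydroxy-5-methoxyphenyl in place of 3-chloro-4-hydroxy-5-methoxyphenyl gives a 1.6-fold lower number from compound 3 to compound 4 (0.21 log units; within the scatter) and stays within the scatter, so the read-out does not tell these two rings apart on this chain, even though the change alters both the halogen and where it sits. Nothing at hand offers an explanation for this result.

The single step changes the halogen and its place together, so the two may have no effect on this chain or may offset each other, and no pair shown separates them. Also open, going by these compounds, is how this chain would respond if a larger or different group, such as iodine, a nitrile or an amine, stood in place of the halogen on the ring, with the hydroxy and methoxy groups and the pivalate ester left as they are.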